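Three limits and one vinyl swap

This account rests on a few compounds, and the source may have more. Where it says the series, first, only, none or still open, it means among the compounds named here.

compound 1 `COC1=C(C)C(=O)/C(=C(O)/C=C/c2cccc(OC)c2)C(=O)C1(C)C`: < 4 ug/mL
compound 2 `COC1=C(C)C(=O)/C(=C(O)/C=C/c2ccc(F)cc2)C(=O)C1(C)C`: < 4 ug/mL
compound 3 `COC1=C(C)C(=O)/C(=C(O)/C=C/c2c(C)cc(C)cc2C)C(=O)C1(C)C`: < 4 ug/mL

In a functional assay on HUVEC cells (Homo sapiens) (on this read-out lower numbers stand for an effect already at smaller amounts and higher numbers for an effect only at larger amounts of compound), compound 2 gives < 4 ug/mL, which is a limit and not a number. The whole set shows the same thing: the limit of < 4 ug/mL in this assay, at which 3 of the 3 values shown sit. Compound 4 `C=Cc1ccccc1/C=C/C(O)=C1/C(=O)C(C)=C(OC)C(C)(C)C1=O` carries 2-vinylphenyl in place of 4-fluorophenyl, on a double-bonded chain carbon bound to a double-bonded chain carbon: 2-vinylphenyl in place of 4-fluorophenyl on a double-bonded chain carbon bound to a double-bonded chain carbon. Among the compounds with values here, the one measured step that bears on this swap is a step that the two limits leave unreadable from compound 1 to compound 2. It offers no size to carry over, so no step beyond the scatter, in either direction, is expected in this assay. The expected change is a step that the limit leaves unreadable from compound 2 to compound 4. For compound 4 the estimated value is 2 ug/mL, with an expected range from 0.6 ug/mL to 5 ug/mL.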

Compound 4, concentration for half-maximal effect: < 1.1 ug/mL
Compound 4 was reported as a limit; the forecaster's own chance of this, stated with the estimate: 75%; at least 1.8-fold (0.25 log units) between middle value and limit.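

In this assay, within the data shown here, compound 1, compound 2 and compound 4 all stand as limits and not numbers, so no step among them can be read. Going by these compounds, whether swapping the aromatic group changes the effect at all, and by how much, stays open.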